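This account rests on a few compounds, and the source may have more. Where it says the series, first, only, none or still open, it means among the compounds named here.

Three compounds share one core and differ only in the aryl group attached to it. Compound 1, `CCC1=C(O)c2c(oc(-c3ccc(CC)cc3)cc2=O)C(CC)(CC)C1=O`, gives 21.9 uM in a functional assay on KB cells (Homo sapiens) for antiproliferative activity, read by sulforhodamine B assay, with a stated time of 3 days; on this read-out lower numbers stand for an effect already at smaller amounts and higher numbers for an effect only at larger amounts of compound. Compound 2, `CCC1=C(O)c2c(oc(-c3ccc(Br)cc3)cc2=O)C(CC)(CC)C1=O`, reaches only a limit in this assay, > 48.1 uM. Compound 3, `CCC1=C(O)c2c(oc(-c3cccc(C)c3)cc2=O)C(CC)(CC)C1=O`, gives 49.7 uM in this assay and so stands highest of the two numbers shown, with compound 1 nearest through the step of a 2.3-fold higher number from compound 1 to compound 3 (0.36 log units; beyond the scatter). The other measured step is an at least 2.1-fold higher number from compound 1 to compound 2 (0.34 log units; beyond the scatter); the step that the limit leaves unreadable from compound 2 to compound 3 cannot be sized because of the limit of > 48.1 uM in this assay, at which 1 of the 3 values shown sits.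

Compound 4, `CCC1=C(O)c2c(oc(-c3cc(C)c(C)cc3C)cc2=O)C(CC)(CC)C1=O`, differs from compound 3 by 2,4,5-trimethylphenyl in place of 3-methylphenyl on an aromatic carbon. The step that bears on it is a 2.3-fold higher number from compound 1 to compound 3 (0.36 log units; beyond the scatter), since it connects the 3-methylphenyl of compound 3 to an aryl group that, like the entering 2,4,5-trimethylphenyl, carries an alkyl at its 4-position. A partial reversal of that step is therefore expected, so compound 4 is expected to give 30 uM in this assay, between 12 uM and 75 uM. The expected step is a 1.7-fold lower number from compound 3 to compound 4 (0.22 log units; within the scatter), modest and toward a lower number.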

Compound 4, concentration for half-maximal effect: 8.2 uM
Estimate against measurement, compound 4: 3.7-fold (0.56 log units) above; the measured number lies below the stated range.
By their numbers in this assay, from the lowest: compound 4; then compound 1; then compound 3.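

The 2,4,5-trimethylphenyl group shows that more methyl substitution on this aryl ring can go with a clearly lower number in this assay, giving a 6.1-fold lower number from compound 3 to compound 4 (0.78 log units; beyond the scatter). It also passes the lowest number seen earlier, with a 2.7-fold lower number from compound 1 to compound 4 (0.43 log units; beyond the scatter), so the best aryl group so far is neither 4-ethylphenyl nor a singly substituted ring. Against the 4-bromophenyl group the change gives an at least 5.8-fold lower number from compound 2 to compound 4 (0.76 log units; beyond the scatter), a step that stands only as a bound: the limit of > 48.1 uM in this assay, at which 1 of the 4 values shown sits.

Which of the three methyl groups carries the step stays open, as the compounds shown do not separate them. Also open, on these data alone, is whether an aryl ring bearing an amine or a carboxylic acid in place of these methyl groups would keep the lower number.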